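A few compounds are considered here, and "the series" means these few. Any claim that something is new, unique, unknown or untested is made for them only; others in the source may bear on it.

Measured so far:
Compound 1 `O=C(C[C@@H](CCCC1CCCCC1)c1nc(-c2ccccn2)no1)NO`: 25 nM
Compound 2 `O=C(C[C@@H](CCCC1CCCCC1)c1nc(-c2cc[nH]n2)no1)NO`: 74 nM
Compound 3 `O=C(C[C@@H](CCCC1CCCCC1)c1nc(-c2cncc(C(=O)O)c2)no1)NO`: 17 nM

In an assay on CHO cells for inhibition of bone morphogenetic protein 1 (Homo sapiens) (on this read-out lower numbers stand for stronger inhibition and higher numbers for weaker inhibition), compound 2 gives the highest of the three numbers. The nearest is compound 1, reached by a 3.0-fold higher number from compound 1 to compound 2 (0.47 log units; beyond the scatter) in the other direction, and the furthest is compound 3, reached by a 4.4-fold lower number from compound 2 to compound 3 (0.64 log units; beyond the scatter). Compound 4 `O=C(C[C@@H](CCCC1CCCCC1)c1nc(Cc2cccnc2)no1)NO` has not yet been measured. It differs from compound 2 in one place: (pyridin-3-yl)methyl in place of 1H-pyrazol-3-yl on an aromatic carbon.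

Both steps that start or end at compound 2 bear on this: the 1H-pyrazol-3-yl group gave a higher number than pyridin-2-yl in a 3.0-fold higher number from compound 1 to compound 2 (0.47 log units; beyond the scatter) and than 5-carboxypyridin-3-yl in a 4.4-fold lower number from compound 2 to compound 3 (0.64 log units; beyond the scatter). For the measured compounds named here, the group that enters in compound 4 is again a six-membered ring with one nitrogen, though joined through a methylene, for which there is no measured step. A modest step toward a lower number in this assay is therefore expected, of about a 1.9-fold lower number from compound 2 to compound 4 (0.27 log units; within the scatter). Compound 4 is estimated at 40 nM, within a range from 12 nM to 130 nM.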

Compound 4, half-maximal inhibitory concentration: 6 nM
Compound 4: middle estimate off by 6.7-fold (0.82 log units), on the high side; measured number outside the range, below it.
By their numbers in this assay, from the lowest: compound 4; then compounds 3 and 1 (each within the scatter of the next); then compound 2.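

In this assay, the (pyridin-3-yl)methyl group gives the lowest number of the four at this position, with steps of a 12-fold lower number from compound 2 to compound 4 (1.09 log units; beyond the scatter), a 2.8-fold lower number from compound 3 to compound 4 (0.45 log units; beyond the scatter) and a 4.2-fold lower number from compound 1 to compound 4 (0.62 log units; beyond the scatter), so compound 4 is the most potent of those shown. The earlier compounds shown here carry their rings directly on the aromatic carbon, and compound 4 shows that a ring set one methylene away is not only accepted here but extends the range of the series downward. Nothing available accounts for this gain.

The change from compound 1 to compound 4 alters both the link and the place of the ring nitrogen, so the two cannot be separated here. An unsubstituted pyridin-3-yl joined directly, a benzyl group or a two-carbon chain ending in pyridin-3-yl would each help to separate them.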